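From compound 1 to compound 3: one carbamoyl addition

A few compounds are considered here, and "the series" means these few. Any claim that something is new, unique, unknown or untested is made for them only; others in the source may bear on it.

In a functional assay on MCF7 cells (Homo sapiens) for inhibition, read by MTT assay, with a stated time of 4 days (a lower number here means a stronger inhibitor, a higher number a weaker inhibitor), compound 1 `COc1cc(NC(C)CCCNC(=O)NN)c2ncccc2c1` gives 16000 nM. For the measured compounds named here, the only other measured compound, compound 2 `CCOC(=O)N(C)C(c1ccccc1)c1ccccc1`, gives 26000 nM. These two values lie within the usual scatter of each other, so they do not rank the compounds. Going by the values given here, no measured pair differs in one place, which leaves no measured step to guide the next one.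

Compound 3 `COc1cc(NC(C)CCCNC(=O)NNC(=O)NC(CO)(CO)CO)c2ncccc2c1` keeps the core of compound 1 and changes in one place: (2-hydroxy-1,1-bis(hydroxymethyl)ethyl)carbamoyl in place of hydrogen on an amine nitrogen. A (2-hydroxy-1,1-bis(hydroxymethyl)ethyl)carbamoyl stands in place of hydrogen on an amine nitrogen, whose other neighbour is an amide-type nitrogen. With no measurement of this change in this assay, any expectation for it is tentative. The expected direction is only a lean toward a higher number, meaning a weaker inhibitor. The estimated size is a 1.8-fold higher number from compound 1 to compound 3 (0.24 log units; within the scatter), which is expected to stay within the scatter, although the wide range allows a larger step in either direction. For compound 3 the estimated value is 28000 nM, with an expected range from 8000 nM to 100000 nM.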

Compound 3, half-maximal inhibitory concentration: 28000 nM
Compound 3: middle estimate and measured number agree at the digits printed, and the stated range covers the measured number.
By their numbers in this assay, from the lowest: compounds 1, 2 and 3 (each within the scatter of the next).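

In this assay, for the compounds shown here, the step of a 1.8-fold higher number from compound 1 to compound 3 (0.24 log units; within the scatter) is the first measured change in one place, and it lies within the scatter. The amine nitrogen whose other neighbour is an amide-type nitrogen thus carries (2-hydroxy-1,1-bis(hydroxymethyl)ethyl)carbamoyl, with its 10 heavy atoms, no ring and no net charge, in place of hydrogen without a step beyond the scatter, something the earlier pair, which differed in more than one place, could not show. No available evidence accounts for the size of this step.

Going by these compounds alone, one substituent at one place gives only a single reading of this nitrogen, so it remains open whether an acetyl, a methylcarbamoyl or a carbamoyl bearing a carboxylic acid would behave in the same way. Also open, as far as these compounds go, is whether a change elsewhere on the core of compound 1, such as a primary amine in place of the methoxy group or a longer chain between the two nitrogens of the side chain, would give a step beyond the scatter in this assay at this level of inhibition.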